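Swapping a Sulfonyl Group for a Trifluoroacetyl Group

A few compounds are considered here, and "the series" means these few. Any claim that something is new, unique, unknown or untested is made for them only; others in the source may bear on it.

Measured compounds and values:
compound 1 `Cc1ccc(S(=O)(=O)N(Cc2cccc(F)c2F)Cc2cn(S(=O)(=O)c3ccc(F)cc3)c3ccccc23)cc1`: -35%
compound 2 `Cc1ccc(S(=O)(=O)N(Cc2cn(Cc3cccc(F)c3F)nn2)Cc2cn(S(=O)(=O)c3ccc(C)cc3)c3ccccc23)cc1`: 71.5%
compound 3 `O=C(N(Cc1cccc(F)c1F)Cc1cn(S(=O)(=O)c2ccc(F)cc2)c2ccccc12)C(F)(F)F`: -52.3%

In a functional assay on 3T3-L1 cells (Mus musculus) for inhibition, with a stated time of 20 min, tested at 20 uM (a lower number here means less inhibition, a higher number more inhibition at the concentration tested (going by the name of the read-out)), compound 2 gives the highest of the three numbers, with compound 1 and compound 3 well beneath it. The change from compound 1 to compound 3 is (trifluoromethyl)carbonyl in place of (4-methylphenyl)sulfonyl on an amine nitrogen, and the step it made was a number 17.3 percentage points lower from compound 1 to compound 3 (beyond the scatter). Compound 4 `Cc1ccc(S(=O)(=O)n2cc(CN(Cc3cn(Cc4cccc(F)c4F)nn3)C(=O)C(F)(F)F)c3ccccc32)cc1` is not yet measured. It arises from compound 2 by (trifluoromethyl)carbonyl in place of (4-methylphenyl)sulfonyl on an amine nitrogen, the same change, made at the same kind of place. How the core of compound 2 differs from the core of compound 1 is not broken down here, so the step may not carry over exactly. Still, going by the earlier step, the expected step from compound 2 to compound 4 in this assay is a number 17.5 percentage points lower from compound 2 to compound 4 (beyond the scatter), a modest fall. Compound 4 is therefore estimated at 54%, with a likely range from 25% to 75%.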

Compound 4, a percentage reported as inhibition, at one concentration (the size of the read-out at that concentration, not a potency): 31.9%
Beside the measured number, compound 4's estimate is 22.1 percentage points above it; the range from low to high includes it.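

In this assay, putting (trifluoromethyl)carbonyl in place of (4-methylphenyl)sulfonyl on the amine nitrogen gives a number 39.6 percentage points lower from compound 2 to compound 4 (beyond the scatter). The direction of the step carries over from one core to the other, but its size does not: the same change on two cores in this assay, a number 17.3 percentage points lower (beyond the scatter) from compound 1 to compound 3 and a number 39.6 percentage points lower (beyond the scatter) from compound 2 to compound 4, 22.3 percentage points apart, beyond the scatter of two such steps. These two pairs show that the fall differs in size between these cores, but they do not show which part of the cores accounts for the difference or how the change would behave on any further core.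

The compounds shown leave open how a smaller group on the same amine nitrogen, such as a plain acetyl or a methanesulfonyl group, would compare. They also leave open how the nitrogen would fare with a simple hydrogen there.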